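Trifluoromethyl in Place of Isopropyl on Compound 2

This account rests on a few compounds, and the source may have more. Where it says the series, first, only, none or still open, it means among the compounds named here.

Values measured so far in a functional assay on SK-MEL-28 cells (Homo sapiens) for inhibition, read by colorimetric assay and MTT assay, with a stated time of 72 h (a higher number here means a weaker inhibitor, a lower number a stronger inhibitor), are these
- Compound 1 `C=CCCCCCOc1ncc(-c2ccccc2OCCCCC=C)n1C` gives 79000 nM
- Compound 2 `C=CCCCCOc1ncc(-c2cc(C(C)C)ccc2OC)n1C` gives 3000 nM

Compound 2 at 3000 nM has the lower of the two numbers and is the stronger inhibitor of the pair. Compound 1 at 79000 nM stands beyond the usual scatter from it. The next compound to be tested is compound 3 `C=CCCCCOc1ncc(-c2cc(C(F)(F)F)ccc2OC)n1C` which carries trifluoromethyl in place of isopropyl on an aromatic carbon, para to a methoxy group. The change is trifluoromethyl in place of isopropyl on an aromatic carbon and nothing else in the structure differs. For the measured compounds named here, no measured pair yet shows what a single change does here, so the expectation rests on compound 2 at 3000 nM alone. The expected step in this assay is a 1.7-fold higher number from compound 2 to compound 3 (0.22 log units; within the scatter) and this estimate is a small rise in the number that may stay within the scatter. Compound 3 is estimated at 5000 nM and its expected range runs from 1500 nM to 16000 nM on this estimate.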

Compound 3, half-maximal inhibitory concentration: 56000 nM
Estimate against measurement, compound 3: 11-fold (1.05 log units) below; the whole stated range lies below it.
By their numbers in this assay, from the lowest: compound 2; then compounds 3 and 1 (each within the scatter of the next).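

In this assay, for the compounds shown here, the group on this aromatic carbon, para to a methoxy group, clearly matters: trifluoromethyl in place of isopropyl gives a 19-fold higher number from compound 2 to compound 3 (1.27 log units; beyond the scatter) in a single-change comparison that the earlier compounds did not offer. The swap is small by count, with 3 heavy atoms leaving and 4 entering, and neither group brings a ring, a hydrogen-bond donor or acceptor, or a net charge, yet isopropyl goes with the stronger inhibitor of this pair. Nothing measured here explains why the number rises.

Going by these compounds, whether a tert-butyl group or an amine on this carbon would stay close to compound 2 remains open. So does whether the same swap would have a similar effect on a compound with a longer chain on the shared core.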